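A few compounds are considered here, and "the series" means these few. Any claim that something is new, unique, unknown or untested is made for them only; others in the source may bear on it.

Compound 1, `COc1cc(-n2cnc3ccc(-c4ccc([N+](=O)[O-])cc4)cc32)cc(OC)c1OC`: 8940 nM in a functional assay on A549 cells (Homo sapiens) for antiproliferative activity, read by MTT assay, with a stated time of 72 h; on this read-out higher numbers stand for weaker inhibition and lower numbers for stronger inhibition
Compound 2, `COc1cc(-n2cnc3ccc(-c4ccc(C)cc4F)cc32)cc(OC)c1OC`: the limit > 10000 nM in this assay

Going by the values given here, compound 1 holds the only true number among the two results; the result for compound 2 is a limit of this assay, not a number. Both results sit at the weak end of what this assay can report. The step from compound 1 to compound 3, `COc1cc(-n2cnc3ccc(-c4ccc(F)cc4)cc32)cc(OC)c1OC`, is fluoro in place of nitro on an aromatic carbon. Among the compounds with values here, one measured step bears on it: an at least 1.1-fold higher number from compound 1 to compound 2 (0.04 log units; that floor lies within the scatter), where 2-fluoro-4-methylphenyl took the place of 4-nitrophenyl and the reading reached (the limit of > 10000 nM in this assay, at which 1 of the 2 values shown sits). That step replaced the nitro group with a ring carrying fluoro and methyl, and it did not improve matters; removing the nitro group in favour of a bare fluoro seems unlikely to move the reading in the other direction. The expected outcome for compound 3 is therefore no change beyond the scatter, or a small weakening, with a real chance that only a limit is reported. Compound 3 is estimated at 11000 nM, with a range from 5000 nM to 25000 nM, the expected step being a 1.2-fold higher number from compound 1 to compound 3 (0.09 log units; within the scatter).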

Compound 3, half-maximal inhibitory concentration: 6740 nM
The estimate for compound 3 lay 1.6-fold (0.21 log units) above the measured number; measured number inside the range.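

Swapping the nitro group for a fluoro, on a six-membered aromatic ring of carbon only and para to a large group, gives a 1.3-fold lower number from compound 1 to compound 3 (0.12 log units; within the scatter) in this assay, so a group of 3 heavy atoms and 2 hydrogen-bond acceptors can give way to a single atom with no acceptors without a change that can be told from the scatter. This shows that the weak reading of compound 1 does not depend on the nitro group, since the fluoro analogue gives a true number in the same range. The comparison with the other fluorinated compound is less firm, with an at least 1.4-fold lower number from compound 2 to compound 3 (0.17 log units; that floor lies within the scatter), and compound 2 has a limit rather than a number: the limit of > 10000 nM in this assay, at which 1 of the 3 values shown sits.

Going by these compounds alone, all three compounds remain at the weak end of this assay, so these results show only that two quite different groups at this position read alike, not what would make inhibition stronger. As far as these compounds go, whether an amine, a hydroxyl or a carboxylic acid at the same position would shift the reading beyond the scatter remains open, as does the effect of leaving the ring without any group there.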